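Removing the Chloro Substituent: Compound 3 in Mice

A few compounds are considered here, and "the series" means these few. Any claim that something is new, unique, unknown or untested is made for them only; others in the source may bear on it.

Measured so far:
compound 1 `CC1CC(=O)N(CC(=O)N2CCN(c3ccc(Cl)cc3)CC2)C1=O` — 100 mg/kg
compound 2 `CC1CC(=O)N(CC(=O)N2CCN(c3cccc(Cl)c3)CC2)C1=O` — 100 mg/kg

In a functional assay on the whole organism (strain CD1) with Mus musculus as the target, in the maximal electroshock model, with a stated time of 0.5 h (on this read-out lower numbers stand for an effect already at smaller amounts and higher numbers for an effect only at larger amounts of compound), compound 1 gives 100 mg/kg and compound 2 gives 100 mg/kg; the step of no change at the digits printed from compound 1 to compound 2 (within the scatter). Compound 2 thus stands level with compound 1. Compound 3 `CC1CC(=O)N(CC(=O)N2CCN(c3ccccc3)CC2)C1=O` differs from compound 2 by hydrogen in place of chloro on an aromatic carbon. Among the compounds with values here, no measured step removes the chloro group outright; the only step available, no change at the digits printed from compound 1 to compound 2 (within the scatter), merely moved it and left the dose unchanged, so little movement is expected, if anything toward a larger dose. Compound 3 is therefore expected at 100 mg/kg, between 50 mg/kg and 300 mg/kg, an expected step of no change at the digits printed from compound 2 to compound 3 (within the scatter).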

Compound 3, minimum effective dose: 300 mg/kg
For compound 3 the middle estimate is 3.0-fold (0.48 log units) below the measured one; the range from low to high includes it.
By their numbers in this assay, from the lowest: compounds 1 and 2 (each within the scatter of the next); then compound 3.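

In this assay, the chloro group matters even though its shift between the two printed places did not: replacing it with hydrogen gives a 3.0-fold higher number from compound 2 to compound 3 (0.48 log units; beyond the scatter), and the same change read from the other isomer gives a 3.0-fold higher number from compound 1 to compound 3 (0.48 log units; beyond the scatter). Among these three compounds, therefore, chloro at either place goes with a smaller effective dose than the unsubstituted phenyl. The data offer no explanation for this difference.

The compounds shown leave open whether fluoro, bromo or methoxy in place of chloro would match the chlorinated compounds, and whether a second chloro group would change the dose further.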